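This account rests on a few compounds, and the source may have more. Where it says the series, first, only, none or still open, it means among the compounds named here.

Working notes on the series. Within the data shown here, in a functional assay on a cell-free system (Platelet, plasma, Homo sapiens) for inhibition (on this read-out higher numbers stand for weaker inhibition and lower numbers for stronger inhibition), compound 2 (`O=C(Nc1cccc(OCc2ccc(F)cc2)c1)C1CCNCC1`) gives 68000 nM, the lower of the two numbers so far, and compound 1 (`N=C(N)N1CCCC(C(=O)Nc2cccc(OCc3ccc(F)cc3)c2)C1`) gives 274000 nM. Compound 3 (`N=C(N)N1CCC(C(=O)Nc2cccc(OCc3ccc(F)cc3)c2)CC1`) has not yet been measured. On the amine nitrogen in the ring of compound 2, the hydrogen atom gives way to a new group: a group of 3 heavy atoms (1 carbon, 2 nitrogen; no ring) in place of a hydrogen atom, on an amine nitrogen in a ring.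

Among the measured compounds shown here, only one measured step bears on this change: a 4.0-fold lower number from compound 1 to compound 2 (0.61 log units; beyond the scatter). Compound 1 carries the entering group, but that step exchanges the whole group on the carbonyl carbon, so it does not isolate the present change. For the measured compounds named here, no matched pair exists for adding this group alone. Read in reverse, the step gives a weak hint of a higher number in this assay once the group is present, and a modest move in that direction is expected, smaller than the measured step. The expected step is a 1.6-fold higher number from compound 2 to compound 3 (0.21 log units; within the scatter), and the uncertainty remains wide in both directions. For compound 3 the estimated value is 110000 nM, with an expected range of 30000 nM to 350000 nM.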

Compound 3, half-maximal inhibitory concentration: 768000 nM
For compound 3 the middle estimate is 7.0-fold (0.84 log units) below the measured one, outside the stated range (above it).
By their numbers in this assay, from the lowest: compound 2; then compound 1; then compound 3.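

In this assay, the group of 3 heavy atoms (1 carbon, 2 nitrogen) can now be read alone on the amine nitrogen in the ring, and an 11-fold higher number from compound 2 to compound 3 (1.05 log units; beyond the scatter) is a large step towards weaker inhibition, so hydrogen on this nitrogen is clearly favoured over the entering group within this pair. The two groups of 9 heavy atoms on the carbonyl carbon have the same atom counts but are not interchangeable, as a 2.8-fold higher number from compound 1 to compound 3 (0.45 log units; beyond the scatter) lies beyond the scatter, and compound 2, which lacks the entering group, has the lowest number of the three. Nothing available explains the size of either step.

As far as these compounds go, it remains open whether a methyl or an acetyl group on the same amine nitrogen would also raise the number relative to the hydrogen of compound 2, or whether the large step is peculiar to the group in compound 3. Also open, from the compounds shown here alone, is how the same addition behaves on a ring amine of the kind in compound 1, where the hydrogen-bearing counterpart would provide the matching pair.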